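The compounds below may be only part of what the source reports. "The series", "measured", "known", "first", "only" and "open" are said of these compounds alone.

Measured so far in an in vitro ADME assay on microsomes from liver (Homo sapiens) for metabolic stability; on this read-out higher numbers stand for fast clearance and lower numbers for slow clearance:
- Compound 1 `CCOC(=O)N(Cc1ccccc1Oc1ccccc1)[C@H]1CCNC1` gives 21 mL.min-1.g-1 as a number
- Compound 2 `CC(=O)N(Cc1ccccc1-c1ccccc1)[C@H]1CCNC1` gives < 7 mL.min-1.g-1 as a limit

Compound 2 stands at a limit of the assay, so no exact number exists for it. Compound 3 `CC(C)S(=O)(=O)N(Cc1ccccc1-c1ccccc1)[C@H]1CCNC1` carries isopropylsulfonyl in place of acetyl on an amine nitrogen and otherwise matches compound 2. Among the measured compounds shown here, no measured pair shows a change of this kind, so the size of the step is a judgement. The expectation starts from compound 2 with its limit < 7 mL.min-1.g-1 as the lower anchor. For the measured compounds named here, compound 1 with 21 mL.min-1.g-1 is the only full number and guides the upper end of the range. A modest rise is expected in this assay, and the result may stay at the limit. The estimated step is an at least 1.4-fold higher number from compound 2 to compound 3 (0.15 log units; that floor lies within the scatter) on this reasoning. Compound 3 is expected at 10 mL.min-1.g-1 with an estimated range of 7 mL.min-1.g-1 to 22 mL.min-1.g-1 in this measurement.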

Compound 3, intrinsic clearance in microsomes: 20 mL.min-1.g-1
Compound 3: the middle estimate sits 2.0-fold (0.30 log units) below what was measured; low and high end bracket the measured number.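

Among the compounds shown here, the first measured pair at this amine nitrogen, whose other neighbours are a saturated chain carbon and a saturated ring carbon, shows that isopropylsulfonyl in place of acetyl gives in this assay an at least 2.8-fold higher number from compound 2 to compound 3 (0.45 log units; beyond the scatter). Compound 2 gives < 7 mL.min-1.g-1, which is a limit and not a number. The step is therefore a floor, and its full size cannot be read: the limit of < 7 mL.min-1.g-1 in this assay, at which 1 of the 3 values shown sits.

The compounds shown do not separate the sulfonyl link from the branched isopropyl chain; methylsulfonyl or an isobutyryl group on the same nitrogen would bear on that question. From the compounds shown here alone, how ethoxycarbonyl compares on the core of compound 2 also stays open, as compound 1 differs from compound 2 and compound 3 in more than one place.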